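The source may hold more compounds than are shown below. What is called first, only, known or untested is meant among the compounds shown, and "the series" means these compounds.

Working notes on the series.

The three measured compounds share one core and differ only in the aryl group on the carbonyl carbon. Compound 1 `COc1cc(-c2nnc3n2NC(c2ccco2)C(C(=O)c2ccc(Br)cc2)S3)cc(OC)c1OC` carries a 4-bromophenyl there; in a functional assay on HepG2 cells (Homo sapiens) for cytotoxicity, read by MTT assay, with a stated time of 48 h (on this read-out lower numbers stand for stronger inhibition and higher numbers for weaker inhibition), compound 1 gives only a limit, > 100000 nM, not a number (the limit of > 100000 nM in this assay, at which 1 of the 3 values shown sits). Compound 2 `COc1cc(-c2nnc3n2NC(c2ccco2)C(C(=O)c2ccc(Cl)cc2)S3)cc(OC)c1OC` carries a 4-chlorophenyl, and in this assay compound 2 gives 78600 nM. Compound 3 `COc1cc(-c2nnc3n2NC(c2ccco2)C(C(=O)c2cccc4ccccc24)S3)cc(OC)c1OC` carries a naphthalen-1-yl; in this assay compound 3 gives 33900 nM, the lowest of the two numbers shown, with compound 2 nearest to it. The steps read an at least 1.2-fold lower number from compound 1 to compound 2 (0.10 log units; that floor lies within the scatter), an at least 2.9-fold lower number from compound 1 to compound 3 (0.46 log units; beyond the scatter) and a 2.3-fold lower number from compound 2 to compound 3 (0.37 log units; beyond the scatter).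

Compound 4 `COc1cccc(C(=O)C2Sc3nnc(-c4cc(OC)c(OC)c(OC)c4)n3NC2c2ccco2)c1` is not yet measured. Its change from compound 3 is 3-methoxyphenyl in place of naphthalen-1-yl on a carbonyl carbon. For the measured compounds named here, the steps that bear on it are the two steps onto the naphthalen-1-yl, from compound 1 and from compound 2, both modest and both towards lower numbers; going from the naphthalen-1-yl to a single six-membered ring is expected to run back the other way, by a modest step of a 1.9-fold higher number from compound 3 to compound 4 (0.28 log units; within the scatter). Compound 4 is therefore estimated at 65000 nM in this assay, within a range from 25000 nM to 160000 nM.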

Compound 4, half-maximal inhibitory concentration: > 100000 nM
Compound 4 ended at the assay's limit; the forecaster's own chance of this, stated with the estimate: 25%; middle value at least 1.5-fold (0.18 log units) away from the limit.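

In this assay, moving from the naphthalen-1-yl to 3-methoxyphenyl on the carbonyl carbon gives an at least 2.9-fold higher number from compound 3 to compound 4 (0.46 log units; beyond the scatter), so a single aromatic ring carrying a methoxy group, not only one carrying a halogen, falls short of compound 3. The comparison with the 4-chlorophenyl gives only an at least 1.2-fold higher number from compound 2 to compound 4 (0.10 log units; that floor lies within the scatter), which does not separate the two groups, and the step between compound 1 and compound 4 cannot be read because both values are limits. Compound 3 now has steps beyond the scatter to all three other compounds, while the upper end of the series is capped: the limit of > 100000 nM in this assay, at which 2 of the 4 values shown sit.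

The compounds shown leave open whether a methoxy group elsewhere on the phenyl ring would read differently. They also leave open what an amine or a carboxylic acid on that ring, or a naphthalen-2-yl on the carbonyl carbon, would give.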